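Cytotoxicity of Three Ureas and an Untested Fourth

A few compounds are considered here, and "the series" means these few. Any claim that something is new, unique, unknown or untested is made for them only; others in the source may bear on it.

Three ureas built on one shared core have been measured: compound 1 `Cc1cc(NC(=O)Nc2ccc(C)c(Cl)c2)c2ccccc2n1`, compound 2 `Cc1cc(NC(=O)Nc2ccccc2F)c2ccccc2n1` and compound 3 `Cc1cc(NC(=O)Nc2cccc(C(N)=O)c2)c2ccccc2n1`. In an ADME assay on Raji cells (Homo sapiens) for cytotoxicity, with a stated time of 72 h (on this read-out higher numbers stand for an effect only at larger amounts of compound and lower numbers for an effect already at smaller amounts), compound 1 reaches only a limit, > 25000 nM. Compound 2 likewise gives only a limit in this assay, > 25000 nM. Compound 3 also gives only a limit in this assay, > 25000 nM. Compound 3 thus stands where every value shown stands, at the limit of > 25000 nM in this assay, at which 3 of the 3 values shown sit. Compound 4 `Cc1cc(NC(=O)Nc2cccc(OC(F)(F)F)c2)c2ccccc2n1` differs from compound 3 by trifluoromethoxy in place of carbamoyl on an aromatic carbon. With no numbered step between measured compounds and all three at the same limit, no step beyond the usual scatter is expected in this assay. Compound 4 is therefore estimated at 30000 nM, with a range from 10000 nM to 100000 nM. The expected step is a step that the limit leaves unreadable from compound 3 to compound 4.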

Compound 4, half-maximal effective concentration: 9000 nM
Beside the measured number, compound 4's estimate is 3.3-fold (0.52 log units) above it; the whole stated range lies above it.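

At this aromatic carbon the choice of group matters in this assay: trifluoromethoxy in place of carbamoyl gives an at least 2.7-fold lower number from compound 3 to compound 4 (0.44 log units; beyond the scatter). Within the data shown here, compound 4 is the first compound here with a real number rather than a limit. The true step may be larger, because compound 3 gives only a limit: the limit of > 25000 nM in this assay, at which 3 of the 4 values shown sit.

Carbamoyl carries a hydrogen-bond donor and trifluoromethoxy carries none, but the compounds shown cannot tell whether that difference or another one counts. From the compounds shown here alone, whether methoxy, trifluoromethyl or a carboxylic acid at this place would also give a readable number stays open.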